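Urea versus amide on the pyrazole series

A few compounds are considered here, and "the series" means these few. Any claim that something is new, unique, unknown or untested is made for them only; others in the source may bear on it.

a functional assay on SF-295 cells (Homo sapiens) for inhibition, read by sulforhodamine B assay, with a stated time of 48 h (a lower number here means that less compound is tolerated, a higher number that more compound is tolerated), is the only read-out covered here. Among the measured compounds shown here, compound 1, `COc1cc(-c2nn(-c3cccc(NC(=O)Nc4cc(C(F)(F)F)cc(C(F)(F)F)c4)c3)cc2-c2ccncc2)ccc1Cl`, gives 3310 nM and is the one compound of the pair with a numeric value. Compound 2, `COc1cc(-c2nn(-c3cccc(NC(=O)c4cccc(C(F)(F)F)c4)c3)cc2-c2ccncc2)ccc1Cl`, carries the corresponding amide in place of the urea and is reported only as a limit, > 50000 nM; it sits at the limit of > 50000 nM in this assay, at which 1 of the 2 values shown sits, so no number is known for it and the distance to compound 1 cannot be stated beyond the fact that compound 1 lies inside the measured range.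

Compound 3, `COc1cc(-c2nn(-c3cccc(NC(=O)Nc4cccc(C(F)(F)F)c4)c3)cc2-c2ccncc2)ccc1Cl`, is not yet measured. It differs from compound 2 by (3-(trifluoromethyl)phenyl)amino in place of 3-(trifluoromethyl)phenyl on a carbonyl carbon. Going from compound 2 to compound 3 restores the urea seen in compound 1 but with a single trifluoromethyl on the terminal ring, so the step is expected to move toward lower concentrations, an at least 4.1-fold lower number from compound 2 to compound 3 (0.61 log units; beyond the scatter), with an appreciable chance that only a limit is returned again. Compound 3 is estimated at 12000 nM, with a range of 3000 nM to 50000 nM, a number that would be expected to stand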

Compound 3, concentration lethal to 50% of the cells: 3200 nM
Compound 3: the middle estimate sits 3.8-fold (0.57 log units) above what was measured; the range from low to high includes it.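

In this assay, (3-(trifluoromethyl)phenyl)amino in place of 3-(trifluoromethyl)phenyl on a carbonyl carbon gives an at least 15-fold lower number from compound 2 to compound 3 (1.19 log units; beyond the scatter), a large step that turns the amide into the urea while the rest of the molecule stays the same. Compound 2 is reported only as a limit of the assay, so the true size of this step remains a bound: the limit of > 50000 nM in this assay, at which 1 of the 3 values shown sits. With the urea in place, hydrogen in place of trifluoromethyl on an aromatic carbon gives a 1.0-fold lower number from compound 1 to compound 3 (0.01 log units; within the scatter), which lies within the scatter, so the second trifluoromethyl of compound 1 brings no measurable difference in this read-out.

Still open, as far as these compounds go, is whether the step from amide to urea depends on the hydrogen of the new amino nitrogen, a question that a urea carrying a methyl group on that nitrogen would address. Also open, from the compounds shown here alone, is how far the terminal ring tolerates other groups in place of the remaining trifluoromethyl, such as a chlorine or a nitrile, and whether a urea with an unsubstituted phenyl ring still stands level with compound 3 in this assay.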